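This account rests on a few compounds, and the source may have more. Where it says the series, first, only, none or still open, it means among the compounds named here.

Measured so far in an assay on nucleic acid for inhibition of Nucleic Acid, read by fluorescence, tested at 100 uM; a higher number here means more inhibition at the concentration tested (going by the name of the read-out), a lower number less inhibition:

Compound 1 `CN(Cc1cn(C2CCCCC2OC(=O)c2ccccc2)nn1)CC1CCCCC1`: in this assay compound 1 gives 32%.
Compound 2 `CN(CCCc1ccccc1)Cc1cn(C2CCCCC2OC(=O)COc2ccccc2)nn1`: in this assay compound 2 gives 42%.
Compound 3 `CN(Cc1cn(C2CCCCC2OC(=O)COc2ccccc2)nn1)CC1CCCCC1`: in this assay compound 3 gives 37%.

Compound 3 stands second of the three numbers, and both its neighbours lie within the usual scatter of it: a number 5 percentage points higher from compound 1 to compound 3 (within the scatter), and a number 5 percentage points lower from compound 2 to compound 3 (within the scatter). None of the three measured compounds can therefore be set apart from the others on these numbers.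

Compound 4 `CCOC(=O)C1CCCN(Cc2cn(C3CCCCC3OC(=O)COc3ccccc3)nn2)C1` is not yet measured. It differs from compound 3 in one place: 3-(ethoxycarbonyl)piperidin-1-yl in place of (cyclohexylmethyl)(methyl)amino on a saturated chain carbon bound to an aromatic carbon.

For the measured compounds named here, the only measured step that bears on this change is the one at the substituent bound to the amine nitrogen, a number 5 percentage points lower from compound 2 to compound 3 (within the scatter), which swapped a cyclohexyl for a phenethyl without moving the read-out beyond the scatter. Going by the values given here, the present change is larger, exchanging the whole amine for a ring that carries an ester, and no measured pair covers it; nothing in the three numbers points to a step in either direction. The expectation for compound 4 is therefore no change beyond the scatter: no change at the digits printed from compound 3 to compound 4 (within the scatter).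

Compound 4 is estimated at 37%, with a range from 22% to 52%.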

Compound 4, a percentage reported as inhibition, at one concentration (the size of the read-out at that concentration, not a potency): 21%
For compound 4 the middle estimate is 16 percentage points above the measured one; measured number outside the range, below it.
By their numbers in this assay, from the lowest: compound 4; then compounds 1, 3 and 2 (each within the scatter of the next).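

In this assay, the place on a saturated chain carbon bound to an aromatic carbon now shows a change that moves the read-out beyond the scatter: a number 16 percentage points lower from compound 3 to compound 4 (beyond the scatter) and a number 21 percentage points lower from compound 2 to compound 4 (beyond the scatter). Both steps bring in the same 3-(ethoxycarbonyl)piperidin-1-yl, so the result holds against two different open-chain amines, whereas exchanging cyclohexyl and phenethyl on the amine nitrogen did not separate compounds 2 and 3. No measurement at hand accounts for this lower number.

Open, on these data alone, is whether the lower number goes with the ethoxycarbonyl group or with the ring that carries it. A plain piperidin-1-yl, or a carboxylic acid in place of the ethyl ester, would separate these two readings.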